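The source may hold more compounds than are shown below. What is called first, only, known or untested is meant among the compounds shown, and "the series" means these compounds.

Compound 1 `CC(=O)c1cc(-c2ccccc2)cc2cc(-c3ccccc3)[nH]c12` was tested in a functional assay on HeLa cells (Homo sapiens) for cytotoxicity, read by MTT assay, with a stated time of 2 days, tested at 100 uM (on this read-out higher numbers stand for a weaker effect at the one concentration tested and lower numbers for a stronger effect), where compound 1 gives 51.4%. Going by the values given here, that is the higher of the two numbers recorded so far; the only other measured compound, compound 2 `COc1ccc(-c2cc3cc(-c4ccccc4)cc(C(C)=O)c3[nH]2)cc1`, gives 32.8% in this assay, and the step of a number 18.6 percentage points lower from compound 1 to compound 2 (beyond the scatter) separates them. Compound 3 `CC(=O)c1cc(/C=C/c2ccc(F)cc2)cc2cc(-c3ccccc3)[nH]c12` has not yet been measured. It differs from compound 1 by 2-(4-fluorophenyl)ethenyl in place of phenyl on an aromatic carbon. Among the compounds with values here, no measured step involves this kind of exchange: the one known step concerns a different change at a different place on the shared core, so it offers no direct guidance for this one. With nothing to anchor a direction, a step of a number 1.4 percentage points lower from compound 1 to compound 3 (within the scatter) is expected, which amounts to no change beyond the scatter. Compound 3 is therefore estimated to give 50% in this assay, with a range from 30% to 70%.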

Compound 3, a percentage reported as activity, at one concentration (the size of the read-out at that concentration, not a potency): 23.9%
For compound 3 the middle estimate is 26.1 percentage points above the measured one, and the stated range ends above it.
By their numbers in this assay, from the lowest: compounds 3 and 2 (each within the scatter of the next); then compound 1.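

In this assay the aromatic carbon meta to the acetyl group now has a step of its own, with a number 27.5 percentage points lower from compound 1 to compound 3 (beyond the scatter) when 2-(4-fluorophenyl)ethenyl takes the place of phenyl. Going by these compounds alone, the earlier step concerned a different place, so this is the first sign that a change at this carbon can strengthen the effect at the one concentration tested, though that single reading is not a potency. No measurement shown here bears on why the number falls.

The double bond and the fluorine enter together, so the compounds shown cannot say which of them goes with the lower number. Also open, from the compounds shown here alone, is what a 2-phenylethenyl group without fluorine, a longer chain or an amine would do at this carbon.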